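Compound 4: a new oxygen substituent at the limit

The source may hold more compounds than are shown below. What is called first, only, known or untested is meant among the compounds shown, and "the series" means these compounds.

Notes on the series around compound 1 `COc1ccc2c(c1)cc(-c1cc(OC)c(OC)c(OC)c1)n2Cc1ccccc1` in a functional assay on PC-3 cells (Homo sapiens) for cytotoxicity, read by MTT assay, with a stated time of 24 h; on this read-out lower numbers stand for stronger inhibition and higher numbers for weaker inhibition. Compound 1 gives > 30000 nM, which is a limit. Compound 2 `COc1ccc2c(c1)cc(-c1cc(OC)c(OC)c(OC)c1)n2Cc1ccc(OCc2ccccc2)cc1` gives > 30000 nM, also a limit. Compound 3 `CCOCC(=O)Oc1ccc(Cn2c(-c3cc(OC)c(OC)c(OC)c3)cc3cc(OC)ccc32)cc1` gives > 30000 nM, again a limit, so all three share (the limit of > 30000 nM in this assay, at which 3 of the 3 values shown sit).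

Compound 4 `COc1ccc2c(c1)cc(-c1cc(OC)c(OC)c(OC)c1)n2Cc1ccc(OC(C)CN(C)C)cc1` follows from compound 3 by one change: 1-((dimethylamino)methyl)ethyl in place of (ethoxymethyl)carbonyl on an oxygen on an aromatic ring. The measured steps give no size: a step that the two limits leave unreadable from compound 1 to compound 2, a step that the two limits leave unreadable from compound 1 to compound 3, a step that the two limits leave unreadable from compound 2 to compound 3. None of them brings in 1-((dimethylamino)methyl)ethyl, so any expectation is weak. Activity is expected to stay close to the limit, with a slight shift towards stronger inhibition at best. The expected step is an at least 1.5-fold lower number from compound 3 to compound 4 (0.17 log units; that floor lies within the scatter). For compound 4 the estimate is 20000 nM, with an expected range of 5000 nM to 40000 nM.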

Compound 4, half-maximal inhibitory concentration: 13300 nM
Estimate against measurement, compound 4: 1.5-fold (0.18 log units) above, and the stated range covers the measured number.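

Of the groups at this place on the oxygen, only 1-((dimethylamino)methyl)ethyl gives a measured number rather than a limit in this assay: the limit of > 30000 nM in this assay, at which 3 of the 4 values shown sit. The change reads as an at least 2.2-fold lower number from compound 3 to compound 4 (0.35 log units; beyond the scatter) and an at least 2.2-fold lower number from compound 2 to compound 4 (0.35 log units; beyond the scatter), and in place of hydrogen on the aromatic carbon as an at least 2.2-fold lower number from compound 1 to compound 4 (0.35 log units; beyond the scatter); each is a minimum, with the true size unknown. The steps among compound 1, compound 2 and compound 3 cannot be read, so only compound 4 separates itself from the others.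

Still open, as far as these compounds go, is whether the dimethylamino nitrogen or the branched chain accounts for the step. A morpholine or a longer unbranched amine chain on the same oxygen would separate the two.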